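The compounds below may be only part of what the source reports. "The series", "measured", "known", "first", "only" and "open" are said of these compounds alone.

Measured compounds in an assay for inhibition of liver carboxylesterase 1 (Homo sapiens), read by spectrophotometry; on this read-out higher numbers stand for weaker inhibition and lower numbers for stronger inhibition:

- compound 1 `O=S(=O)(Nc1ccc(NS(=O)(=O)c2ccc(F)cc2)cc1)c1ccc(F)cc1`: in this assay compound 1 gives > 100000 nM, which is a limit of the assay and not a number.
- compound 2 `O=S(=O)(Nc1c(F)c(F)c(NS(=O)(=O)c2ccc(Br)cc2)c(F)c1F)c1ccc(Br)cc1`: in this assay compound 2 gives > 100000 nM, again only a limit.

Within the data shown here, compound 1 therefore stands nowhere on a numerical scale: its value is a limit, and the same holds for the one other measured compound, as the limit of > 100000 nM in this assay, at which 2 of the 2 values shown sit, shows. Among the measured compounds shown here, no pair of measured compounds differs in one place, so no step of known size is available, and the two values give no direction to read.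

Compound 3 `COc1ccc(S(=O)(=O)Nc2ccc(NS(=O)(=O)c3ccc(F)cc3)cc2)cc1` differs from compound 1 by methoxy in place of fluoro on an aromatic carbon. With both measured values sitting at the limit, nothing in the series shows a change of this kind moving the read-out in either direction.

Compound 3 is accordingly expected to remain at the limit of this assay, with an estimate of 100000 nM spanning 30000 nM to 300000 nM. The expected step of a number no higher from compound 1 to compound 3 (the limit leaves the size open) is none beyond the scatter, and a numerical value for compound 3 is expected only in a minority of runs.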

Compound 3, inhibition constant: > 100000 nM
Compound 3: a limit, no number; the forecaster's own chance of this, stated with the estimate: 80%; the middle value lies on the limit itself.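

In this assay compound 3 gives > 100000 nM, a limit and not a number. Compound 1 also rests on a limit, and the change from 4-fluorophenyl to 4-methoxyphenyl gives no readable step between the two compounds. The compounds shown leave open which change to the shared core, if any, would give a numerical value: the limit of > 100000 nM in this assay, at which 3 of the 3 values shown sit.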